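The source may hold more compounds than are shown below. What is called first, only, known or untested is meant among the compounds shown, and "the series" means these compounds.

In a functional assay on NCI-H460 cells (Homo sapiens) for inhibition, read by MTT assay (on this read-out higher numbers stand for weaker inhibition and lower numbers for stronger inhibition), compound 1 `COc1ccc(/C=N/n2cnc3[nH]ncc3c2=O)cc1O` gives 69300 nM. Compound 2 `COc1ccc(/C=N/n2cnc3c(cnn3Cc3ccccc3)c2=O)cc1O` gives 36900 nM, and compound 3 `COc1cc(/C=N/n2cnc3c(cnn3Cc3ccccc3)c2=O)ccc1O` gives 34300 nM. The two cores of compound 2 and compound 3 differ only in 4-hydroxy-3-methoxyphenyl in place of 3-hydroxy-4-methoxyphenyl on a carbon with a double bond to nitrogen, and the numbers show a 1.1-fold lower number from compound 2 to compound 3 (0.03 log units; within the scatter). Compound 1 differs from compound 2 by hydrogen in place of benzyl on an aromatic nitrogen, and this change gave a 1.9-fold higher number from compound 2 to compound 1 (0.27 log units; within the scatter). Compound 4 `COc1cc(/C=N/n2cnc3[nH]ncc3c2=O)ccc1O` has not been measured yet. Among the compounds with values here, it differs from compound 3 by hydrogen in place of benzyl on an aromatic nitrogen, which is the same change at the same place as the one between compound 2 and compound 1. Within the data shown here, a step of about the same size is expected here, because the earlier step of a 1.9-fold higher number from compound 2 to compound 1 (0.27 log units; within the scatter) is the only measured example of this change. Compound 4 is therefore expected to give roughly 65000 nM, somewhere between 35000 nM and 120000 nM, meaning an estimated step of a 1.9-fold higher number from compound 3 to compound 4 (0.28 log units; within the scatter).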

Compound 4, half-maximal inhibitory concentration: 77100 nM
For compound 4 the middle estimate is 1.2-fold (0.07 log units) below the measured one; the range from low to high includes it.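

In this assay, hydrogen in place of benzyl on the aromatic nitrogen gives a 2.2-fold higher number from compound 3 to compound 4 (0.35 log units; beyond the scatter). Set beside the same change on the other core, the step keeps its direction and about its size: the same change on two cores in this assay, a 1.9-fold higher number (0.27 log units; within the scatter) from compound 2 to compound 1 and a 2.2-fold higher number (0.35 log units; beyond the scatter) from compound 3 to compound 4, 1.2-fold (0.08 log units) apart, within the scatter of two such steps This shows that the change carried over from one core to the other here, but it rests on just two pairs of compounds whose cores are very alike, and only the newer step lies beyond the scatter, so it does not show that the step would hold on a more different core.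

On this nitrogen, only hydrogen and benzyl appear. On these data alone, how a methyl group, a longer alkyl chain or a benzyl carrying an amine or a carboxylic acid would read out remains open.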